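This account rests on a few compounds, and the source may have more. Where it says the series, first, only, none or still open, it means among the compounds named here.

Measured compounds and their values in this study:

Compound 1, `CCN(Cc1ccccn1)c1ccc(C(=O)N2CCc3ccc(OS(N)(=O)=O)cc3C2)cc1`: 87.7%
Compound 2, `CCN(Cc1ccccc1)Cc1ccc(S(=O)(=O)N2CCc3ccc(OS(N)(=O)=O)cc3C2)cc1`: 31%
Compound 3, `CN(C)CCN(Cc1ccccc1)c1cccc(C(=O)N2CCc3ccc(OS(N)(=O)=O)cc3C2)c1`: 28.6%

All three were tested in an assay on HEK293 cells for inhibition of Steryl-sulfatase (Homo sapiens), tested at 1 uM; on this read-out lower numbers stand for a weaker effect and higher numbers for a stronger effect at the one concentration tested. Compound 1 gives 87.7%, the highest of the three numbers. Compound 2 gives 31%, which is lower than compound 1 by more than the usual scatter. Compound 3 gives 28.6%, the furthest from compound 1 and again lower by more than the scatter. No pair among these three differs in only one place, so their values show no isolated step; compounds 2 and 3 both carry a benzyl group on the nitrogen, but each differs from compound 1 in further places as well.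

Compound 4, `CCN(Cc1ccccc1)c1ccc(C(=O)N2CCc3ccc(OS(N)(=O)=O)cc3C2)cc1`, has not yet been measured. It differs from compound 1 in one place only: phenyl in place of pyridin-2-yl on a saturated chain carbon bound to a nitrogen on an aromatic ring. Among the measured compounds shown here, there is no measured pair that isolates this change, so its effect can only be guessed from compound 1 itself. A modest step is expected, most likely downward, and possibly no step beyond the scatter, giving a number 12.7 percentage points lower from compound 1 to compound 4 (beyond the scatter). Compound 4 is therefore expected to reach about 75%, with a range from 45% to 92%.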

Compound 4, a percentage reported as inhibition, at one concentration (the size of the read-out at that concentration, not a potency): 83.6%
Beside the measured number, compound 4's estimate is 8.6 percentage points below it; the range from low to high includes it.
By their numbers in this assay, from the lowest: compounds 3 and 2 (each within the scatter of the next); then compounds 4 and 1 (each within the scatter of the next).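

In this assay, among the compounds shown here, exchanging pyridin-2-yl for phenyl on a saturated chain carbon bound to a nitrogen on an aromatic ring gives a number 4.1 percentage points lower from compound 1 to compound 4 (within the scatter) and, unlike the earlier compounds, this pair isolates a single change. The ring nitrogen of pyridin-2-yl, the one hydrogen-bond acceptor that leaves with this group, can therefore be given up at this place without a change beyond the usual scatter, and a ring of carbon only serves as well on this read-out, although a reading at one concentration cannot show whether the two compounds share the same potency. No measurement shown here accounts for this result.

The compounds shown leave open how far this tolerance extends, for instance to pyridin-3-yl, to a saturated cyclohexyl ring or to a longer chain between the ring and the nitrogen, since only these two aromatic rings have been compared at this place. They also leave open which of their several differences from compound 1 and compound 4 separates compound 2 and compound 3 from that pair, as none of those comparisons rests on a single change.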